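The source may report more compounds than this note shows. Statements on the series, on what has been measured and on what is new or still open speak of the compounds shown alone.

Measured so far, in a functional assay on HT-29 cells (Homo sapiens) for inhibition, read by MTT assay, with a stated time of 72 h; on this read-out lower numbers stand for stronger inhibition of growth and higher numbers for weaker inhibition of growth:
compound 1 `O=S(=O)(NCCNCc1ccc(-c2ccccc2)cc1)c1cc(C(F)(F)F)cc(C(F)(F)F)c1` gives 2700 nM
compound 2 `O=S(=O)(NCCCNCc1ccc(C(F)(F)F)cc1)c1cc(C(F)(F)F)cc(C(F)(F)F)c1` gives 2900 nM
compound 3 `O=S(=O)(NCCNCc1cccc2ccccc12)c1cc(C(F)(F)F)cc(C(F)(F)F)c1` gives 16000 nM

All three share the same core and differ in the linking chain and in the aryl group at the benzylic end. Compound 2 gives the second highest number of the three. Compound 1 lies within the scatter of compound 2, so the two cannot be ordered. Compound 3 gives a higher number than compound 2, and that gap lies beyond the scatter.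

Compound 4 `O=S(=O)(NCCCNCc1ccc(Br)cc1)c1cc(C(F)(F)F)cc(C(F)(F)F)c1` is not yet measured. It differs from compound 2 in one place: bromo in place of trifluoromethyl on an aromatic carbon. Within the data shown here, no pair of measured compounds differs by a single change, so there is no measured step to lean on, and nothing among compounds 1 to 3 shows how this assay responds to trifluoromethyl giving way to bromo at that position. The expectation is for no step beyond the scatter in this assay in either direction: a 1.0-fold higher number from compound 2 to compound 4 (0.01 log units; within the scatter). Compound 4 is estimated at 3000 nM, with a range from 1200 nM to 8000 nM.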

Compound 4, concentration for 50% growth inhibition: 2200 nM
Estimate against measurement, compound 4: 1.4-fold (0.13 log units) above, and the stated range covers the measured number.
By their numbers in this assay, from the lowest: compounds 4, 1 and 2 (each within the scatter of the next); then compound 3.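

In this assay, a 1.3-fold lower number from compound 2 to compound 4 (0.12 log units; within the scatter) gives the series its first single-place step. At this aromatic carbon, para to a large group, 4-(trifluoromethyl)benzyl can give way to 4-bromobenzyl, with four heavy atoms replaced by one, and the number stays within the scatter. No measurement at hand bears on the reason for this outcome.

As far as these compounds go, whether other groups at this position, such as an amine, a carboxylic acid or a nitrile, would also stay within the scatter remains open. The effect of the linking chain alone also cannot be read, since compound 1 and compound 3 each differ from compound 2 in more than one place, and a pair with the same aryl group and a different chain is still needed.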